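Three Limits, One Ring Nitrogen, and a New Sulfonyl Group

The source may report more compounds than this note shows. Statements on the series, on what has been measured and on what is new or still open speak of the compounds shown alone.

Compound 3 `COC(=O)c1ccc(C2SCC(=O)N2c2ccc(N3CCN(Cc4ccc(Cl)c(Cl)c4)CC3)cn2)c(OC)c1` was tested in a functional assay on NALM-6 cells (Homo sapiens) for antiproliferative activity, read by MTT assay and trypan blue exclusion, with a stated time of 72 h; on this read-out higher numbers stand for weaker inhibition and lower numbers for stronger inhibition. In this assay compound 3 gives > 100000 nM, which is a limit of the assay rather than a number. Compound 1 `COC(=O)c1ccc(C2SCC(=O)N2c2ccc(N3CCN(Cc4cc(OC)c(OC)c(OC)c4)CC3)cn2)c(OC)c1` gives in this assay > 100000 nM, also a limit. Compound 2 `COC(=O)c1ccc(C2SCC(=O)N2c2ccc(N3CCN(S(=O)(=O)c4ccc(F)cc4)CC3)cn2)c(OC)c1` gives in this assay > 100000 nM, again a limit. The step that the two limits leave unreadable from compound 1 to compound 3 and the step that the two limits leave unreadable from compound 2 to compound 3 cannot be read because all three values sit at the same limit (the limit of > 100000 nM in this assay, at which 3 of the 3 values shown sit). Compound 4 `COC(=O)c1ccc(C2SCC(=O)N2c2ccc(N3CCN(S(=O)(=O)c4c(C)cc(C)cc4C)CC3)cn2)c(OC)c1` differs from compound 3 in one place: (2,4,6-trimethylphenyl)sulfonyl in place of 3,4-dichlorobenzyl on an amine nitrogen in a ring. Among the compounds with values here, the two measured steps that change the group on this ring nitrogen carry no readable size, so no direction can be drawn from them; they show only that three different groups on this nitrogen all leave the measured value at the limit. Compound 4 is expected to behave the same way, with an estimated step that the limit leaves unreadable from compound 3 to compound 4 that stays within the scatter. The estimate for compound 4 is 150000 nM, expected to fall between 40000 nM and 600000 nM, most likely reported as a limit once more.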

Compound 4, half-maximal inhibitory concentration: > 100000 nM
Compound 4 ended at the assay's limit; the forecaster's own chance of this, stated with the estimate: 88%; the middle value lies beyond the limit too.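

No new step can be read, neither from compound 3 to compound 4 nor from compound 2 to compound 4, because every value is a limit and not a number: the limit of > 100000 nM in this assay, at which 4 of the 4 values shown sit.

The compounds shown leave open whether any group on this ring nitrogen gives a measurable value.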